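Swapping a Polar Tail for a Plain Hydrocarbon Tail

The compounds below may be only part of what the source reports. "The series", "measured", "known", "first", "only" and "open" are said of these compounds alone.

Two measured compounds share one core and differ only in the tail attached to the amide nitrogen. Compound 1 `CCCCCCCCCCCC(=O)OC[C@H](CSC[C@@H](N)C(=O)NCCCC(C)(C)CO)OC(=O)CCCCCCCCCCC` gives 30700 nM in an assay on HEK293 cells for agonist activity at Toll-like receptor 2 (Homo sapiens); a lower number here means that less compound is needed, a higher number that more compound is needed for the effect. Compound 2 `CCCCCCCCCCCC(=O)OC[C@H](CSC[C@@H](N)C(=O)NCCOCCOS(=O)(=O)O)OC(=O)CCCCCCCCCCC` gives 61 nM in this assay, and so compound 2 stands with the lower of the two numbers measured. Among the compounds with values here, the single step available, a 500-fold lower number from compound 1 to compound 2 (2.70 log units; beyond the scatter), shows how strongly this assay answered to a change in that tail. Compound 3 `CCCCCCCCCCCC(=O)OC[C@H](CSC[C@@H](N)C(=O)NC(C)CCC(C)C)OC(=O)CCCCCCCCCCC` takes the change (1,4-dimethylpentyl in place of 2-(2-(sulfooxy)ethoxy)ethyl on an amide-type nitrogen), which removes every hydrogen-bond donor and acceptor from the tail and leaves a branched hydrocarbon there. Within the data shown here, this runs against the direction of the one measured step, so a large rise in the number is expected, a 490-fold higher number from compound 2 to compound 3 (2.69 log units; beyond the scatter). Compound 3 is therefore estimated to give 30000 nM in this assay, with a range from 4000 nM to 200000 nM.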

Compound 3, half-maximal effective concentration: 190 nM
The estimate for compound 3 lay 160-fold (2.20 log units) above the measured number; the measured number lies below the stated range.
By their numbers in this assay, from the lowest: compound 2; then compound 3; then compound 1.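

A low number in this assay does not depend on the 2-(2-(sulfooxy)ethoxy)ethyl tail: 1,4-dimethylpentyl, with 0 hydrogen-bond donors and 0 hydrogen-bond acceptors, in its place gives only a 3.1-fold higher number from compound 2 to compound 3 (0.49 log units; beyond the scatter). Set against the other tail, the same 1,4-dimethylpentyl group gives a 160-fold lower number from compound 1 to compound 3 (2.21 log units; beyond the scatter), so among these three compounds the hydrocarbon tail stands much closer to the sulfooxy tail than to 4-(hydroxymethyl)-4-methylpentyl, and the large first step cannot be read as a simple gain from adding the sulfooxy group. Nothing available here accounts for this order of the three tails.

A plain 4,4-dimethylpentyl tail would show whether the hydroxyl group is what sets compound 1 apart. A carboxylic acid at the end of the tail would show whether another acid group can match the sulfooxy tail of compound 2.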